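Chloro to methoxy on the shared core

The source may hold more compounds than are shown below. What is called first, only, known or untested is meant among the compounds shown, and "the series" means these compounds.

Compound 1 `Fc1ccc(-c2[nH]c3cc(Cl)ccc3c2Cn2ccnc2)cc1` is the anchor of the set. In an ADME assay on MCF7 cells (Homo sapiens) for cytotoxicity, read by MTT assay, with a stated time of 48 h (on this read-out higher numbers stand for weaker inhibition and lower numbers for stronger inhibition), compound 1 gives 41500 nM. Compound 2 `Clc1ccc(-c2[nH]c3cc(Cl)ccc3c2Cn2ccnc2)cc1` differs from it in one place: fluoro in place of chloro on an aromatic carbon. Compound 2 reaches only a limit of this assay, > 1000000 nM. Compound 3 `COc1ccc(-c2[nH]c3cc(Cl)ccc3c2Cn2ccnc2)cc1` also reaches only a limit, > 1000000 nM. Both steps, an at least 24-fold higher number from compound 1 to compound 2 (1.38 log units; beyond the scatter) and an at least 24-fold higher number from compound 1 to compound 3 (1.38 log units; beyond the scatter), rest on (the limit of > 1000000 nM in this assay, at which 2 of the 3 values shown sit).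

From compound 2 to compound 3 the change is methoxy in place of chloro on an aromatic carbon; it gave a step that the two limits leave unreadable from compound 2 to compound 3. Compound 4 `COc1ccc2c(Cn3ccnc3)c(-c3ccc(F)cc3)[nH]c2c1` carries the same kind of change against compound 1, (methoxy in place of chloro on an aromatic carbon), but the place differs: there it is para to a large group, here it is part of a fused or bridged system of two rings, meta to a fused ring and para to a fused ring. With the measured step unreadable, the expectation rests on compound 1 alone, 41500 nM; in this assay the expected step is a 2.4-fold higher number from compound 1 to compound 4 (0.38 log units; beyond the scatter). Compound 4 is estimated at 100000 nM, between 25000 nM and 1000000 nM.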

Compound 4, half-maximal inhibitory concentration: > 1000000 nM
Compound 4: no number, only a limit (the forecaster's own chance of this, stated with the estimate: 40%); at least 10-fold (1.00 log units) between middle value and limit.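

In this assay, methoxy in place of chloro on an aromatic carbon of the fused system gives an at least 24-fold higher number from compound 1 to compound 4 (1.38 log units; beyond the scatter), so at this place the change takes compound 4 to a limit of the assay and not to a number. The same change at the other place, from compound 2 to compound 3, joins two limits and cannot be read, so the series does not show whether the change carries from one place to the other. The size of the new step is only a lower bound, and it rests on a limit: the limit of > 1000000 nM in this assay, at which 3 of the 4 values shown sit.

Still open, going by these compounds, is how an amine or a carboxylic acid would read at either place. On these data alone, it is also open whether any change to compound 1 gives a lower number.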